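Trimming a methyl from the core of compound 1

The compounds below may be only part of what the source reports. "The series", "measured", "known", "first", "only" and "open" are said of these compounds alone.

Compound 1 `Cc1nc(-c2ccccc2NCC2=NCCN2)n(C)n1`: 1000 nM
Compound 2 `CCn1ccc(-c2ccccc2NCC2=NCCN2)n1`: 25.1 nM

In an in vitro functional assay on cells (Fibroblast) for agonist activity at Alpha-1A adrenergic receptor (Homo sapiens) (on this read-out higher numbers stand for an effect only at larger amounts of compound and lower numbers for an effect already at smaller amounts), compound 1 gives 1000 nM, the highest of the two numbers recorded; compound 2 gives 25.1 nM, a gap beyond the usual scatter. Compound 3 `Cn1ncnc1-c1ccccc1NCC1=NCCN1` is not yet measured. It differs from compound 1 by hydrogen in place of methyl on an aromatic carbon, the change sitting on an aromatic carbon of a five-membered aromatic ring with 3 nitrogen, between two ring nitrogen atoms. For the measured compounds named here, no measured pair shows such a step here, so only a small shift in either direction, within or just beyond the scatter, is expected. For compound 3 the estimate is 700 nM (range 200 nM to 2500 nM), an expected step of a 1.4-fold lower number from compound 1 to compound 3 (0.15 log units; within the scatter).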

Compound 3, half-maximal effective concentration: 2 nM
Compound 3: the middle estimate sits 350-fold (2.54 log units) above what was measured; measured number below the stated range.
By their numbers in this assay, from the lowest: compound 3; then compound 2; then compound 1.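

On this assay the swap of methyl for hydrogen gives a 500-fold lower number from compound 1 to compound 3 (2.70 log units; beyond the scatter) and so marks this carbon, between two ring nitrogen atoms, as a highly sensitive position. The loss of a single heavy atom is enough for a large change, so even the smallest group here matters in this series. No available evidence accounts for the size of this step.

The compounds shown leave open how other groups on this carbon, such as an amine, a hydroxyl or a longer chain, would behave. They also leave open whether the same swap would have a similar effect on a different core.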